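The compounds below may be only part of what the source reports. "The series", "measured", "known", "first", "only" and "open" are said of these compounds alone.

Measured compounds: compound 1 `CC(C)(C)n1ncc(OCc2nnc(-c3cccc(F)c3)o2)c(Cl)c1=O` with 7.1 ug/mL; compound 2 `CC(C)(C)n1ncc(OCc2nnc(-c3cc(F)c(F)cc3F)o2)c(Cl)c1=O` with 75.7 ug/mL.

Among the measured compounds shown here, in a functional assay on the whole organism for inhibition, with Mythimna separata as the target, with a stated time of 5 days (on this read-out higher numbers stand for an effect only at larger amounts of compound and lower numbers for an effect already at smaller amounts), compound 2 stands highest of the two numbers, with compound 1 as its only neighbour. Compound 3 `CC(C)(C)n1ncc(OCc2nnc(-c3c(F)cccc3F)o2)c(Cl)c1=O` carries 2,6-difluorophenyl in place of 2,4,5-trifluorophenyl on an aromatic carbon. For the measured compounds named here, only one measured step bears on this ring: an 11-fold higher number from compound 1 to compound 2 (1.03 log units; beyond the scatter), which went from one fluorine to three. Compound 3 returns to fewer fluorines than compound 2, though in a pattern without direct precedent among these compounds, so a partial move back toward compound 1 is expected. The step expected is a 2.5-fold lower number from compound 2 to compound 3 (0.40 log units; beyond the scatter). Compound 3 is estimated at 30 ug/mL, ranging from 8 ug/mL to 120 ug/mL.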

Compound 3, half-maximal effective concentration: 45.4 ug/mL
For compound 3 the middle estimate is 1.5-fold (0.18 log units) below the measured one; the range from low to high includes it.
By their numbers in this assay, from the lowest: compound 1; then compounds 3 and 2 (each within the scatter of the next).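

In this assay, the two rings with several fluorines cannot be told apart (a 1.7-fold lower number from compound 2 to compound 3 (0.22 log units; within the scatter)), so the change from 2,4,5-trifluorophenyl to 2,6-difluorophenyl makes no clear difference here. The single fluorine of compound 1 still stands apart from the 2,6-difluorophenyl ring (a 6.4-fold higher number from compound 1 to compound 3 (0.81 log units; beyond the scatter)), so among these three compounds, more than one fluorine goes with needing larger amounts, and none goes against this. Nothing measured here explains this. Going by these compounds, it remains open how a methoxy group or an amine on this phenyl ring would compare, and whether a single fluorine elsewhere on the ring would match compound 1.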